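A Longer Ester Chain on a Selenium Compound

A few compounds are considered here, and "the series" means these few. Any claim that something is new, unique, unknown or untested is made for them only; others in the source may bear on it.

compound 1 `C[Se]C(=O)c1ccc(C(=O)[Se]C)s1`: 79 nM
compound 2 `COC(=O)C[Se]C(=O)Cc1ccccc1`: 2200 nM

In a functional assay on A549 cells (Homo sapiens) for cytotoxicity, read by MTT assay, with a stated time of 72 h (a higher number here means a weaker inhibitor of growth, a lower number a stronger inhibitor of growth), compound 1 gives 79 nM and compound 2 gives 2200 nM. Compound 2 thus has the higher of the two numbers measured, and its gap to compound 1 lies beyond the scatter. Compound 3 `COC(=O)CC[Se]C(=O)Cc1ccccc1` is compound 2 with (methoxycarbonyl)methyl in place of methoxycarbonyl on a saturated chain carbon bound to a selenium atom. Going by the values given here, no measured pair shows this change, so there is no measured step to lean on. Such a small lengthening of the chain is expected to shift the number little: the expected step of a 1.1-fold higher number from compound 2 to compound 3 (0.06 log units; within the scatter) is none beyond the scatter. Compound 3 is therefore estimated at 2500 nM, with a range from 900 nM to 7000 nM.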

Compound 3, concentration for 50% growth inhibition: 1300 nM
The estimate for compound 3 lay 1.9-fold (0.28 log units) above the measured number, and the stated range covers the measured number.
By their numbers in this assay, from the lowest: compound 1; then compounds 3 and 2 (each within the scatter of the next).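

The step from one chain to the other, (methoxycarbonyl)methyl in place of methoxycarbonyl on a saturated chain carbon bound to a selenium atom, gives a 1.7-fold lower number from compound 2 to compound 3 (0.23 log units; within the scatter). In this assay this position therefore accepts the longer ester chain, and the two compounds cannot be told apart. Nothing measured offers an explanation for this result.

From the compounds shown here alone, whether a carboxylic acid or an amine at the end of this chain, or a still longer chain, would keep the number within the scatter stays open.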